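A few compounds are considered here, and "the series" means these few. Any claim that something is new, unique, unknown or untested is made for them only; others in the source may bear on it.

In an ADME assay on microsomes from liver (Mus musculus) for metabolic stability (a lower number here means that the compound disappears faster, a higher number that the compound lasts longer), the compounds share one core and differ in the group on a saturated chain carbon bound to an aromatic carbon and a saturated chain carbon. Compound 1 (`CC(C)C(Cc1nnc[nH]1)c1ccc(-c2ccc3cccc(F)c3c2)[nH]c1=O`) returns only a limit of the assay (< 0.0667 h). Compound 2 (`CC(C)C(c1ccc(-c2ccc3cccc(F)c3c2)[nH]c1=O)N1CCCCC1=O`) gives 0.0967 h in this assay as its half-life. Compound 3 (`Cc1nc(C(c2ccc(-c3ccc4cccc(F)c4c3)[nH]c2=O)C(C)C)[nH]c1C`) gives 0.0817 h and so stands within the scatter of compound 2.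

Compound 4 (`CC(C)C(c1cnc(N)s1)c1ccc(-c2ccc3cccc(F)c3c2)[nH]c1=O`) carries 2-amino-1,3-thiazol-5-yl in place of 4,5-dimethyl-1H-imidazol-2-yl at that same place (2-amino-1,3-thiazol-5-yl in place of 4,5-dimethyl-1H-imidazol-2-yl on a saturated chain carbon bound to an aromatic carbon and a saturated chain carbon). Three exchanges on this carbon bear on it: (an at least 1.4-fold higher number from compound 1 to compound 2 (0.16 log units; that floor lies within the scatter)) and (an at least 1.2-fold higher number from compound 1 to compound 3 (0.08 log units; that floor lies within the scatter)) and (a 1.2-fold lower number from compound 2 to compound 3 (0.07 log units; within the scatter)). None of the three is shown to go beyond the scatter, and the two that start from compound 1 are known only as floors. A new group here is therefore expected to move the half-life little. The expected change is no shift beyond the scatter (a 1.0-fold lower number from compound 3 to compound 4 (0.01 log units; within the scatter)). For compound 4 the half-life is estimated at 0.08 h with an expected range from 0.05 h to 0.14 h in this assay as well.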

Compound 4, half-life: 0.08 h
Beside the measured number, compound 4's estimate shows no gap at the digits printed; measured number inside the range.
By their numbers in this assay, from the lowest: compounds 4, 3 and 2 (each within the scatter of the next). At a limit, below all of these: compound 1.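

In this assay, placing 2-amino-1,3-thiazol-5-yl on this saturated chain carbon gives a 1.0-fold lower number from compound 3 to compound 4 (0.01 log units; within the scatter), and the exchange for 2-oxopiperidin-1-yl gives a 1.2-fold lower number from compound 2 to compound 4 (0.08 log units; within the scatter). The three groups measured with a number at this carbon, 2-oxopiperidin-1-yl, 4,5-dimethyl-1H-imidazol-2-yl and now a sulfur-bearing ring, thus all stand within the scatter of one another, which two compounds alone could not show. The exchange for (4H-1,2,4-triazol-3-yl)methyl adds only a floor, an at least 1.1-fold higher number from compound 1 to compound 4 (0.07 log units; that floor lies within the scatter).

Going by these compounds, compound 1 holds only a limit of the assay, and how far it lies from the other compounds stays open: the limit of < 0.0667 h in this assay, at which 1 of the 4 values shown sits. Also open is whether a carboxylic acid, a primary amine or a longer chain on this carbon would move the half-life beyond the scatter.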